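The source may hold more compounds than are shown below. What is called first, only, known or untested is meant among the compounds shown, and "the series" means these compounds.

Two compounds in this series share one core, and both were tested in a functional assay on SV5A8 cells (Homo sapiens) for cytotoxicity; a higher number here means a weaker inhibitor, a lower number a stronger inhibitor. Compound 1 `Cc1ccc2c(NCc3ccc(NC(=O)C4CCN(Cc5ccc(Cl)cc5)CC4)cc3)nc(N(C)C)nc2c1` gives > 3180 nM there, which is a limit of the assay and not a number. Compound 2 `COc1ccc(CN2CCC(C(=O)Nc3ccc(CNc4nc(N(C)C)nc5cc(C)ccc45)cc3)CC2)cc1` likewise gives > 6180 nM in this assay, again a limit rather than a number. The step that the two limits leave unreadable from compound 1 to compound 2 therefore cannot be read, because the limit of > 3180 nM in this assay, at which 1 of the 2 values shown sits, and the limit of > 6180 nM in this assay, at which 1 of the 2 values shown sits, both sit at the edge of what the assay reports. Compound 2 thus stands only at a limit, with no number to set it beside compound 1. Compound 3 `Cc1ccc2c(NCc3ccc(NC(=O)C4CCN(Cc5ncc[nH]5)CC4)cc3)nc(N(C)C)nc2c1` differs from compound 2 by 1H-imidazol-2-yl in place of 4-methoxyphenyl on a saturated chain carbon bound to an amine nitrogen in a ring. Among the compounds with values here, no measured step bears directly on this change; the one step in hand, a methoxy group for a chloro group, was itself unreadable. The step that the limit leaves unreadable from compound 2 to compound 3 is therefore expected to be small, if any. Compound 3 is expected to give 8000 nM, within 3000 nM to 30000 nM, most likely again as a limit.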

Compound 3, half-maximal inhibitory concentration: > 20000 nM
Compound 3 ended at the assay's limit; the forecaster's own chance of this, stated with the estimate: 70%; middle value at least 2.5-fold (0.39 log units) from the limit.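

In this assay compound 3 gives > 20000 nM, which is a limit and not a number. Within the data shown here, no step among compound 1, compound 2 and compound 3 can be read, as all three stand at limits. On these data alone, whether 4-chlorophenyl, 4-methoxyphenyl or 1H-imidazol-2-yl makes any difference in this place stays open.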